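The compounds below may be only part of what the source reports. "The series", "measured", "known", "first", "only" and "open" are said of these compounds alone.

The measured compounds:

compound 1, `COc1ccc(Cc2cnc(CCc3ccc(-c4ccccc4C(=O)O)cc3)[nH]2)cc1`, 5360 nM
compound 2, `Cc1cccc(Cc2cnc(CCc3ccc(-c4ccccc4C(=O)O)cc3)[nH]2)c1`, 4310 nM
compound 3, `O=C(O)c1ccccc1-c1ccc(CCc2ncc(Cc3cccc(F)c3)[nH]2)cc1`, 159 nM

These values come from an in vitro functional assay on cells for agonist activity at Bombesin receptor subtype-3 (Homo sapiens), read by luminescence and calcium flux; a lower number here means that less compound is needed, a higher number that more compound is needed for the effect. Compound 3 stands lowest of the three, with compound 2 nearest at a 27-fold lower number from compound 2 to compound 3 (1.43 log units; beyond the scatter) and compound 1 furthest at a 34-fold lower number from compound 1 to compound 3 (1.53 log units; beyond the scatter), both steps well beyond the scatter. Between compound 1 and compound 2 the difference is only a 1.2-fold lower number from compound 1 to compound 2 (0.09 log units; within the scatter).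

Compound 4, `N#Cc1cccc(Cc2cnc(CCc3ccc(-c4ccccc4C(=O)O)cc3)[nH]2)c1`, differs from compound 3 in one place: cyano in place of fluoro on an aromatic carbon. Within the data shown here, two measured steps bear on this position. The step from compound 2 to compound 3, a 27-fold lower number from compound 2 to compound 3 (1.43 log units; beyond the scatter), shows that exchanging the group on this aromatic carbon can move the number a great deal, and the step of a 34-fold lower number from compound 1 to compound 3 (1.53 log units; beyond the scatter) points the same way. Among the measured compounds shown here, no cyano-bearing compound has been measured, so the direction is not settled by these data; what is known is that fluoro gave by far the lowest number and that the other two groups tried gave much higher ones. On that basis compound 4 is expected to give a higher number than compound 3, a step of about a 3.8-fold higher number from compound 3 to compound 4 (0.58 log units; beyond the scatter), with wide uncertainty. The estimate for compound 4 in this assay is 600 nM, within a range of 150 nM to 3000 nM.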

Compound 4, half-maximal effective concentration: 812 nM
The estimate for compound 4 lay 1.4-fold (0.13 log units) below the measured number; the range from low to high includes it.
By their numbers in this assay, from the lowest: compound 3; then compound 4; then compounds 2 and 1 (each within the scatter of the next).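

In this assay, among these compounds, the group on this aromatic carbon now has a third member that lands in the wide gap the earlier compounds left open, with a 5.1-fold higher number from compound 3 to compound 4 (0.71 log units; beyond the scatter) when cyano replaces fluoro and yet a 5.3-fold lower number from compound 2 to compound 4 (0.72 log units; beyond the scatter) when cyano replaces methyl. The comparison with the 4-methoxyphenyl group runs the same way, with a 6.6-fold lower number from compound 1 to compound 4 (0.82 log units; beyond the scatter) on going to the 3-cyanophenyl group, so the numbers at this position no longer fall into just one low value and a high pair; fluoro still gives the lowest number, but cyano keeps part of the gain over methyl. The data on hand offer no explanation for this order among fluoro, cyano and methyl.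

The compounds shown leave open where chloro, trifluoromethyl, hydroxyl or an amine on this same aromatic carbon would fall relative to fluoro and cyano. They also leave open whether the order of fluoro and cyano would hold in 4-fluorophenyl and 4-cyanophenyl groups, which would separate the effect of the group from that of its place on the ring.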